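Swapping a dimethoxyphenyl for a methoxypyridine on the shared core

This account rests on a few compounds, and the source may have more. Where it says the series, first, only, none or still open, it means among the compounds named here.

Of the compounds shown here, two have been tested in a functional assay on MCF7 cells (Homo sapiens) for cytotoxicity, read by sulforhodamine B assay, with a stated time of 72 h; on this read-out higher numbers stand for weaker inhibition and lower numbers for stronger inhibition. Compound 1 `CCS(=O)(=O)Nc1cc(-c2ccc3ncnc(Nc4cccc(F)c4)c3c2)cnc1OC` carries a 3-fluorophenyl on a nitrogen on an aromatic ring, and in this assay compound 1 gives 8020 nM. Compound 2 `CCS(=O)(=O)Nc1cc(-c2ccc3ncnc(Nc4ccc(OC)c(OC)c4)c3c2)cnc1OC` carries a 3,4-dimethoxyphenyl in that place, and in this assay compound 2 gives 2430 nM. Among the compounds with values here, the only step measured so far is a 3.3-fold lower number from compound 1 to compound 2 (0.52 log units; beyond the scatter), so compound 2 stands as the lower of the two numbers, and the gap to compound 1 is beyond the usual scatter.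

Compound 3 `CCS(=O)(=O)Nc1cc(-c2ccc3ncnc(Nc4ccc(OC)nc4)c3c2)cnc1OC` is the next one to be measured. It differs from compound 2 in one place: 6-methoxypyridin-3-yl in place of 3,4-dimethoxyphenyl on a nitrogen on an aromatic ring. Within the data shown here, no measured step matches this exact change. Among the measured compounds shown here, the single step from compound 1 to compound 2 shows only that the aryl group on this nitrogen can move the number by a modest amount. Compound 3 keeps one methoxy but loses the other and gains a ring nitrogen, so for compound 3 the expected outcome is a small rise in the number, a 1.6-fold higher number from compound 2 to compound 3 (0.22 log units; within the scatter), possibly within the scatter. The estimate for compound 3 is 4000 nM, expected between 1500 nM and 11000 nM.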

Compound 3, half-maximal inhibitory concentration: 3770 nM
Beside the measured number, compound 3's estimate is 1.1-fold (0.03 log units) above it, within the range that was stated.
By their numbers in this assay, from the lowest: compounds 2 and 3 (each within the scatter of the next); then compound 1.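

In this assay, the change at this position gives a 1.6-fold higher number from compound 2 to compound 3 (0.19 log units; within the scatter) and so cannot be told apart from no change at all, even though the group goes from 10 heavy atoms to 8, loses a methoxy and gains a ring nitrogen. Measured against the 3-fluorophenyl, the same 6-methoxypyridin-3-yl group gives a 2.1-fold lower number from compound 1 to compound 3 (0.33 log units; beyond the scatter) and so, like the 3,4-dimethoxyphenyl of compound 2, stands apart from compound 1; among these three compounds, both groups carrying methoxy give lower numbers than the group carrying fluorine, and no compound here goes against that. Nothing measured alongside these numbers accounts for this, so the reason for the pattern remains unknown.

Within the data shown here, with only two changes made at once in the step from compound 2 to compound 3, the methoxy and the ring nitrogen cannot be separated, and a plain 4-methoxyphenyl on this nitrogen would be the group to pull them apart. On these data alone, how an amine or a carboxylic acid on this aryl ring would read also stays open.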